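Phenylimidazole series: amino for hydroxy on the phenyl ring

This account rests on a few compounds, and the source may have more. Where it says the series, first, only, none or still open, it means among the compounds named here.

Measured so far:
compound 1, `Nc1ccc(Cl)cc1-c1cnc[nH]1`: 12100 nM
compound 2, `Cn1cncc1-c1ccccc1N`: 1700000 nM
compound 3, `Cn1cncc1-c1cc(Cl)ccc1O`: 17000 nM

All three were run in an assay on cells for inhibition of Indoleamine 2,3-dioxygenase 1 (Homo sapiens), read by HPLC, with a stated time of 20 min; a higher number here means a weaker inhibitor, a lower number a stronger inhibitor. Compound 3 sits at the second highest of the three numbers. Its nearest neighbour is compound 1, whose number is lower by an amount within the scatter, so the two cannot be ordered. Compound 2 stands far above both, well beyond the scatter.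

Compound 4, `Cn1cncc1-c1cc(Cl)ccc1N`, has not been measured. It differs from compound 3 in one place: amino in place of hydroxy on an aromatic carbon. Within the data shown here, no measured pair shows this exact exchange, so the size of the step has no direct precedent. Compound 1, which also carries an amino group on the phenyl ring, gives 12100 nM, close to compound 3, which suggests no large shift either way. The step from compound 3 to compound 4 in this assay is estimated as a 1.2-fold higher number from compound 3 to compound 4 (0.07 log units; within the scatter), which is expected to lie within or near the scatter. Compound 4 is therefore expected to give about 20000 nM, with a range of 5000 nM to 120000 nM.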

Compound 4, half-maximal inhibitory concentration: 1200000 nM
Compound 4: middle estimate off by 60-fold (1.78 log units), on the low side, outside the stated range (above it).
By their numbers in this assay, from the lowest: compounds 1 and 3 (each within the scatter of the next); then compounds 4 and 2 (each within the scatter of the next).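

In this assay, with the methyl on the aromatic nitrogen in place, amino in place of hydroxy on this aromatic carbon proves a large change (a 71-fold higher number from compound 3 to compound 4 (1.85 log units; beyond the scatter)), although the exchange leaves the counted hydrogen-bond donors and acceptors unchanged. The chloro group para to this position makes no readable difference among the amino compounds, and compound 2 and compound 4 cannot be ordered (a 1.4-fold lower number from compound 2 to compound 4 (0.15 log units; within the scatter)). With amino held fixed, methyl in place of hydrogen on the aromatic nitrogen also gives a large step (a 99-fold higher number from compound 1 to compound 4 (2.00 log units; beyond the scatter)).

Nothing shown gives a reason for either large step. Open, going by these compounds, is how a methoxy group or a fluoro group on this same aromatic carbon would read, and whether hydroxy holds its number without the methyl on the aromatic nitrogen.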